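The compounds below may be only part of what the source reports. "The series", "measured", "known", "first", "only" and "open" are said of these compounds alone.

Compound 3 carries a tert-butoxycarbonyl group on the pyrrolidine nitrogen of the shared core, `CN1CCN(c2ccc(Nc3ncc4nc(Nc5ccc(F)cc5)n([C@H]5CCN(C(=O)OC(C)(C)C)C5)c4n3)cc2)CC1`. In a functional assay on A-431 cells (Homo sapiens) for antiproliferative activity, read by MTT assay, with a stated time of 72 h (on this read-out lower numbers stand for stronger inhibition and higher numbers for weaker inhibition), compound 3 gives "not determined" (no result reported), so there is no single number on which to place it. Its closest neighbours give little more: compound 2, `CN1CCN(c2ccc(Nc3ncc4nc(Nc5ccccc5)n([C@H]5CCN(C(=O)OC(C)(C)C)C5)c4n3)cc2)CC1`, differs only in the aniline and in this assay compound 2 gives "not determined" (no result reported). Among the measured compounds shown here, the only number in the set belongs to compound 1, `CN1CCN(c2ccc(Nc3ncc4nc(Nc5ccc(F)cc5)n([C@H]5CCCN(C(=O)CO)C5)c4n3)cc2)CC1`, which carries a different ring and a different group on that ring; in this assay compound 1 gives 3000 nM.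

Compound 4, `CN1CCN(c2ccc(Nc3ncc4nc(Nc5ccc(F)cc5)n([C@H]5CCN(S(=O)(=O)C6CC6)C5)c4n3)cc2)CC1`, differs from compound 3 by cyclopropylsulfonyl in place of tert-butoxycarbonyl on an amine nitrogen in a ring.

For the measured compounds named here, no step between measured compounds exists for this change, and compound 3 itself has no number, so the direction and size of the step from compound 3 to compound 4 in this assay cannot be read from the data. The value of compound 1 is the only anchor, and it is two changes away. Compound 4 is therefore expected to give roughly 1500 nM, with a wide range from 300 nM to 8000 nM, an estimate that rests on compound 1 alone.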

Compound 4, half-maximal inhibitory concentration: 1670 nM
The estimate for compound 4 lay 1.1-fold (0.05 log units) below the measured number; measured number inside the range.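

Among the compounds shown here, the result puts the first number on a pyrrolidine at this position: in this assay the change of ring and nitrogen substituent together gives a 1.8-fold lower number from compound 1 to compound 4 (0.25 log units; within the scatter) and so leaves 1-(cyclopropylsulfonyl)pyrrolidin-3-yl and 1-((hydroxymethyl)carbonyl)piperidin-3-yl indistinguishable on this read-out. Steps that involve compound 2 or compound 3 cannot be read, so the exchange of tert-butoxycarbonyl for cyclopropylsulfonyl on the amine nitrogen of the ring still has no size of its own. The data offer no evidence on the cause of this result.

Because ring and substituent change together in the one readable step, the compounds shown do not separate the contribution of ring size from that of the group on the nitrogen. They also leave open how a methylsulfonyl group, an acetyl group or a longer chain ending in an amine would read on that same pyrrolidine nitrogen, and whether the aniline fluorine matters once a number exists for the pair without it.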